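The source may report more compounds than this note shows. Statements on the series, on what has been measured and on what is new or still open speak of the compounds shown alone.

Working notes on the series. Compound 1 `CC(C)(C)OC(=O)c1cn(C[C@H]2CN(c3ccc(C4=CCS(=O)(=O)CC4)c(F)c3)C(=O)O2)nn1` carries a tert-butoxycarbonyl on an aromatic carbon of the five-membered aromatic ring with 3 nitrogen; in an assay for binding affinity to Amine oxidase [flavin-containing] A (Homo sapiens) (on this read-out higher numbers stand for weaker inhibition and lower numbers for stronger inhibition), compound 1 gives 3500 nM. Compound 2 `CCc1cn(C[C@H]2CN(c3ccc(C4=CCS(=O)(=O)CC4)c(F)c3)C(=O)O2)nn1` has ethyl in place of tert-butoxycarbonyl on an aromatic carbon. For compound 2 this assay reports only a limit, > 200000 nM. The step of an at least 57-fold higher number from compound 1 to compound 2 (1.75 log units; beyond the scatter) is therefore anchored on (the limit of > 200000 nM in this assay, at which 1 of the 2 values shown sits), and its true size is not known beyond that lower bound.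

Compound 3 `O=C1O[C@@H](Cn2ccnn2)CN1c1ccc(C2=CCS(=O)(=O)CC2)c(F)c1` is the next step out from compound 2: hydrogen in place of ethyl on an aromatic carbon. Within the data shown here, only one measured step exists, and it concerns a different exchange at the same aromatic carbon, tert-butoxycarbonyl to ethyl; no measured pair covers ethyl to hydrogen. Compound 2 already stands at the limit, so there is no measured room for a worse number and no evidence for a better one. The step to compound 3 is estimated as a number no higher from compound 2 to compound 3 (the limit leaves the size open), that is, none beyond the scatter. Compound 3 is expected at 200000 nM, within 60000 nM to 600000 nM, most likely again as a limit.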

Compound 3, inhibition constant: 3400 nM
Estimate against measurement, compound 3: 59-fold (1.77 log units) above; the measured number lies below the stated range.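

Hydrogen in place of ethyl on this aromatic carbon gives an at least 58-fold lower number from compound 2 to compound 3 (1.76 log units; beyond the scatter) in this assay, which shows that the unsubstituted ring needs no group at this position to give a measurable value, though the true size of the step is known only as a lower bound: the limit of > 200000 nM in this assay, at which 1 of the 3 values shown sits. The second new step, a 1.0-fold lower number from compound 1 to compound 3 (0.01 log units; within the scatter), puts the hydrogen and tert-butoxycarbonyl forms level, so the two cannot be told apart at this position in this read-out. Of the three groups shown here, only ethyl goes with a limit, so the large step seen earlier belongs to the arrival of ethyl and cannot be read as the simple loss of tert-butoxycarbonyl.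

Going by these compounds, whether ethyl stands alone or marks a wider trend stays open, and a methyl, a longer chain, an amine or a carboxylic acid on this aromatic carbon would bear on that question. The compounds shown also leave open how far compound 2 truly lies from the other two, and whether any group at this position can give a lower number than hydrogen does in compound 3.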